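The compounds below may be only part of what the source reports. "The series", "measured", "known", "first", "only" and "open" are said of these compounds alone.

Three compounds have been measured in an assay on microsomes for inhibition of Amine oxidase [flavin-containing] A (Homo sapiens), read by fluorescence and spectrophotometry, with a stated time of 20 min; on this read-out higher numbers stand for weaker inhibition and lower numbers for stronger inhibition:

Compound 1, `O=c1ccoc2ccc(OCCCc3ccccc3)cc12`, gives 1910 nM.
Compound 2, `O=c1ccoc2ccc(OCc3cccc(Cl)c3)cc12`, gives 424 nM.
Compound 3, `Cc1ccc(COc2ccc3occc(=O)c3c2)cc1`, gives 3490 nM.

Compound 2 has the lowest number of the three, and its gaps to compound 1 and to compound 3 both lie beyond the usual scatter, so it is the strongest inhibitor among them. Compound 4, `N#Cc1cccc(COc2ccc3occc(=O)c3c2)c1`, keeps the shared core of compound 2 and differs from it in a single place: cyano in place of chloro on an aromatic carbon, that carbon being meta to a large group. Among the measured compounds shown here, no two measured compounds differ in just one place, so there is no measured step to lean on. In this assay a modest move toward a higher number is expected, around the edge of the scatter. Compound 4 is therefore estimated at 800 nM, within 250 nM to 2500 nM, an expected step of a 1.9-fold higher number from compound 2 to compound 4 (0.28 log units; within the scatter).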

Compound 4, half-maximal inhibitory concentration: 255 nM
Beside the measured number, compound 4's estimate is 3.1-fold (0.50 log units) above it; the measured number falls inside the stated range.
By their numbers in this assay, from the lowest: compounds 4 and 2 (each within the scatter of the next); then compounds 1 and 3 (each within the scatter of the next).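

Among the compounds shown here, this is the first comparison in the set that changes only one place: in this assay, cyano in place of chloro on this aromatic carbon gives a 1.7-fold lower number from compound 2 to compound 4 (0.22 log units; within the scatter). The two groups therefore cannot be told apart at this position, even though cyano brings a triple bond and a hydrogen-bond acceptor that chloro lacks. Nothing available explains this match. On these data alone, what an amine, a carboxylic acid or a methoxy group on this carbon would give remains open, as does whether the match between cyano and chloro holds in other compounds.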